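Bromo to Nitro on the Aroyl Ring

The source may report more compounds than this note shows. Statements on the series, on what has been measured and on what is new or still open speak of the compounds shown alone.

compound 1 `COc1ccc(Nc2nc(N)c(C(=O)c3ccccc3)s2)cc1`: 230 nM
compound 2 `COc1ccc(Nc2nc(N)c(C(=O)c3ccc(Br)cc3)s2)cc1`: 16 nM

In a functional assay on MOLT-4 cells (Homo sapiens) for antiproliferative activity, read by cell counting, with a stated time of 2 days (on this read-out lower numbers stand for stronger inhibition and higher numbers for weaker inhibition), compound 2 holds the lower of the two numbers, at 16 nM, while compound 1 gives 230 nM. Going by the values given here, the one measured step, a 14-fold lower number from compound 1 to compound 2 (1.16 log units; beyond the scatter), is large and lies beyond the scatter. It came with bromo in place of hydrogen on an aromatic carbon.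

The next compound, compound 3 `COc1ccc(Nc2nc(N)c(C(=O)c3ccc([N+](=O)[O-])cc3)s2)cc1`, keeps the shared core and changes a single group: nitro in place of bromo on an aromatic carbon. This is nitro in place of bromo on an aromatic carbon, para to a large group. Among the compounds with values here, only that one step bears on the change, and no measured compound carries nitro, so the data do not show how nitro compares with bromo. The large size of a 14-fold lower number from compound 1 to compound 2 (1.16 log units; beyond the scatter) shows that a change at this place can move the number a long way. A moderate rise in this assay is therefore expected, to a number still under that of compound 1. The expected step is a 3.1-fold higher number from compound 2 to compound 3 (0.49 log units; beyond the scatter). For compound 3 the estimate is 50 nM, with an expected range of 14 nM to 200 nM.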

Compound 3, half-maximal inhibitory concentration: 29 nM
Beside the measured number, compound 3's estimate is 1.7-fold (0.24 log units) above it; the range from low to high includes it.
By their numbers in this assay, from the lowest: compounds 2 and 3 (each within the scatter of the next); then compound 1.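

In this assay, the aromatic carbon para to a large group has now carried two different groups, and the exchange of bromo for nitro gives a 1.8-fold higher number from compound 2 to compound 3 (0.26 log units; within the scatter) and so does not separate the two. Nitro in place of hydrogen gives a 7.9-fold lower number from compound 1 to compound 3 (0.90 log units; beyond the scatter) and thus also stands clear of the scatter, which shows that the drop in the number at this place is not confined to bromo. It appears with a group of one heavy atom and no hydrogen-bond acceptors and also with a group of three heavy atoms and two hydrogen-bond acceptors, although the nitro step is modest where the bromo step, a 14-fold lower number from compound 1 to compound 2 (1.16 log units; beyond the scatter), is large. Nothing measured here explains why either group lowers the number relative to hydrogen.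

With only bromo and nitro shown at this place, it remains open whether an amine, a carboxylic acid or a longer chain such as propyl would keep the number near those of compound 2 and compound 3 or return it towards that of compound 1. On these data alone, it also remains open whether these steps would hold with a different group elsewhere on the shared core, which all three compounds keep unchanged.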